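The source may hold more compounds than are shown below. What is called first, only, known or untested is meant among the compounds shown, and "the series" means these compounds.

Three compounds share one core and differ in the group attached to a saturated chain carbon bound to an aromatic carbon. In an assay on cells for displacement of a labelled ligand from corticotropin-releasing factor receptor 1 (Homo sapiens), with a stated time of 100 min (a lower number here means a stronger inhibitor, a higher number a weaker inhibitor), compound 1 `CCCN(CC1CC1)C(=O)c1c(C)nc2n(-c3c(C)cc(C)cc3C)c(Cl)cn12` gives 61 nM. Compound 2 `CCN(Cc1c(C(F)(F)F)nc2n(-c3c(C)cc(C)cc3C)c(Cl)cn12)CC1CC1` gives 9 nM, and compound 3 `CCCN(CCC(F)(F)F)Cc1c(C(F)(F)F)nc2n(-c3c(C)cc(C)cc3C)c(Cl)cn12` gives 12 nM, so compound 3 holds the second highest of the three numbers, nearest to compound 2 and farthest from compound 1. Going by the values given here, the one measured step at this position, a 1.3-fold higher number from compound 2 to compound 3 (0.12 log units; within the scatter), stayed within the scatter. Compound 4 `Cc1cc(C)c(-n2c(Cl)cn3c(CN4CCCCC4)c(C(F)(F)F)nc23)c(C)c1` carries piperidin-1-yl in place of propyl(3,3,3-trifluoropropyl)amino on a saturated chain carbon bound to an aromatic carbon. Since that single earlier swap of amine groups moved nothing beyond the scatter, the step of a 1.3-fold higher number from compound 3 to compound 4 (0.10 log units; within the scatter) is expected to be small, in no sure direction. Compound 4 is therefore estimated at 15 nM, within a range of 5 nM to 45 nM.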

Compound 4, inhibition constant: 1200 nM
Beside the measured number, compound 4's estimate is 80-fold (1.90 log units) below it; measured number above the stated range.
By their numbers in this assay, from the lowest: compounds 2 and 3 (each within the scatter of the next); then compound 1; then compound 4.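

This position does not tolerate every amine: in this assay, piperidin-1-yl brings a 100-fold higher number from compound 3 to compound 4 (2.00 log units; beyond the scatter) and a 130-fold higher number from compound 2 to compound 4 (2.12 log units; beyond the scatter), so the small earlier step between two open-chain amines did not hold for a ring. The change swaps open chains for a six-membered ring and also lowers the heavy-atom count, so two differences arrive together. No measurement here gives a cause for this loss. From the compounds shown here alone, it remains open whether the ring or the smaller size matters; diethylamino, an open-chain amine, or azepan-1-yl, a larger ring, could help separate the two.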